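Changing the nitrogen group at the assay limit

The source may hold more compounds than are shown below. What is called first, only, known or untested is meant among the compounds shown, and "the series" means these compounds.

Measured in a toxicity assay on HT-29 cells (Homo sapiens) for cytotoxicity; a lower number here means that less compound is tolerated, a higher number that more compound is tolerated:
Compound 1 `CC(C)n1nc(C(=O)N[C@H]2COc3ccccc3N(C)C2=S)nc1Cc1ccccc1`: > 100000 nM
Compound 2 `CN1C(=S)[C@@H](NC(=O)c2nc(Cc3ccccc3)n(CCCF)n2)COc2ccccc21`: > 100000 nM
Compound 3 `CN1C(=S)[C@@H](NC(=O)c2nc(Cc3ccccc3)n(CCCC#N)n2)COc2ccccc21`: > 100000 nM

Compound 3 stands at > 100000 nM, which is a limit and not a number. The same holds for the whole set, with the limit of > 100000 nM in this assay, at which 3 of the 3 values shown sit.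

Compound 4 `CN1C(=S)[C@@H](NC(=O)c2nc(Cc3ccccc3)n(C3CCCCCC3)n2)COc2ccccc21` has cycloheptyl in place of 3-cyanopropyl on an aromatic nitrogen. It therefore brings a seven-membered non-aromatic ring where compound 3 has no ring in that group.

Three measured steps change this same group. Among the measured compounds shown here, the first is a step that the two limits leave unreadable from compound 1 to compound 2. The second is a step that the two limits leave unreadable from compound 1 to compound 3. The third is a step that the two limits leave unreadable from compound 2 to compound 3. None has a readable size, and no ring on this nitrogen has been measured yet. All three compounds nevertheless sit at the same limit, so no step beyond the scatter is expected in this assay, and no direction can be favoured. The estimated step is a number no higher from compound 3 to compound 4 (the limit leaves the size open). For compound 4 the expected value is 100000 nM. The estimated range for compound 4 runs from 40000 nM to 150000 nM.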

Compound 4, half-maximal cytotoxic concentration: > 100000 nM
Compound 4: a limit, no number (the forecaster's own chance of this, stated with the estimate: 80%); the middle value lies on the limit itself.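

In this assay compound 4 gives > 100000 nM as a limit and not a number, so its steps from compound 1, compound 2 and compound 3 cannot be read. Whether these groups on the aromatic nitrogen differ at all in this assay stays open, because every compound shown sits at the same limit: the limit of > 100000 nM in this assay, at which 4 of the 4 values shown sit.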